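Hydroxy in place of methyl at the chain end

The source may report more compounds than this note shows. Statements on the series, on what has been measured and on what is new or still open speak of the compounds shown alone.

Measured in a functional assay on cells (Homo sapiens) for antiproliferative activity, read by MTT assay, with a stated time of 48 h; a higher number here means a weaker inhibitor, a lower number a stronger inhibitor
- compound 1 `CN(C)CCn1c(N)c(-c2nc3ccccc3[nH]2)c2nc(C#N)c(C#N)nc21` gives 43500 nM
- compound 2 `CN1CCN(CCn2c(N)c(-c3nc4ccccc4[nH]3)c3nc(C#N)c(C#N)nc32)CC1` gives 9110 nM
- compound 3 `CCCn1c(N)c(-c2nc3ccccc3[nH]2)c2nc(C#N)c(C#N)nc21` gives > 50000 nM as a limit, not a number

Compound 3 stands at > 50000 nM as a limit of the assay, not a number. Compound 4 `N#Cc1nc2c(-c3nc4ccccc4[nH]3)c(N)n(CCO)c2nc1C#N` differs from it by hydroxy in place of methyl on a saturated chain carbon, two bonds along the chain from an aromatic nitrogen, so that propyl becomes 2-hydroxyethyl.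

Three measured steps act at this same place. The first (an at least 1.1-fold higher number from compound 1 to compound 3 (0.06 log units; that floor lies within the scatter)) has a floor within the scatter, while the other two (an at least 5.4-fold higher number from compound 2 to compound 3 (0.73 log units; beyond the scatter) and a 4.8-fold lower number from compound 1 to compound 2 (0.68 log units; beyond the scatter)) go beyond it, and both of those involve the 4-methylpiperazin-1-yl group. Going by the values given here, no measured compound carries hydroxy, so these steps guide the expectation only loosely.

A small change toward a lower number in this assay is expected, and the estimated step (an at least 1.4-fold lower number from compound 3 to compound 4 (0.15 log units; that floor lies within the scatter)) may stay within the scatter. The estimate for compound 4 is 35000 nM (expected range 12000 nM to 70000 nM).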

Compound 4, half-maximal inhibitory concentration: > 50000 nM
Compound 4: a limit, no number; the forecaster's own chance of this, stated with the estimate: 40%; at least 1.4-fold (0.15 log units) between middle value and limit.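

In this assay compound 4 gives > 50000 nM, which is a limit of the assay and not a number. Against the 4-methylpiperazin-1-yl chain there is an at least 5.4-fold higher number from compound 2 to compound 4 (0.73 log units; beyond the scatter), so the hydroxy end, like the methyl end, gives up what that group shows, while against the dimethylamino chain there is only an at least 1.1-fold higher number from compound 1 to compound 4 (0.06 log units; that floor lies within the scatter). The step from methyl to hydroxy itself cannot be read, and the reading stops at the same place for both chain ends: the limit of > 50000 nM in this assay, at which 2 of the 4 values shown sit.

The compounds shown leave open how far past that limit either chain end lies, and so whether hydroxy changes anything at all. They also leave open whether a longer chain ending in hydroxy, or a morpholine on the same chain, would reach the range of the 4-methylpiperazin-1-yl compound.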